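Fluoro for chloro on the fused ring of compound 1

The source may hold more compounds than are shown below. What is called first, only, known or untested is meant among the compounds shown, and "the series" means these compounds.

Measured in a functional assay for agonist activity at 5-hydroxytryptamine receptor 4 (Cavia porcellus); on this read-out higher numbers stand for larger maximal responses and lower numbers for smaller maximal responses:
compound 1, `CC(C)n1c(=O)n(C(=O)NCCN2CCN(C)CC2)c2cc(Cl)ccc21`, gives 0.7
compound 2, `CC(C)n1c(=O)n(C(=O)NCCCN2CCN(C)CC2)c2ccccc21`, gives < 0.3, which is a limit of the assay and not a number
compound 3, `CCCN1CCN(CCNC(=O)n2c(=O)n(C(C)C)c3ccccc32)CC1`, gives 0.68

Compound 1 and compound 3 sit within the usual scatter of each other, so neither can be placed above the other. Among the compounds with values here, the one measured step, a number at least 0.38 higher from compound 2 to compound 3 (beyond the scatter), lies on the chain side of the molecule rather than on the fused ring, so it does not bear on the change at hand; the limit of < 0.3 in this assay, at which 1 of the 3 values shown sits, is the only other evidence. Compound 4, `CC(C)n1c(=O)n(C(=O)NCCN2CCN(C)CC2)c2cc(F)ccc21`, differs from compound 1 by fluoro in place of chloro on an aromatic carbon. Within the data shown here, with no measured step at that place, no shift beyond the scatter is expected: the estimated step is a number 0.050 lower from compound 1 to compound 4 (within the scatter). Compound 4 is expected to give about 0.65, between 0.4 and 0.9.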

Compound 4, intrinsic activity: the largest response reached, as a fraction of the reference agonist's: 0.67
Compound 4: the middle estimate sits 0.020 below what was measured; low and high end bracket the measured number.
By their numbers in this assay, from the lowest: compounds 4, 3 and 1 (each within the scatter of the next). At a limit, below all of these: compound 2.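

In this assay, fluoro in place of chloro on this aromatic carbon gives a number 0.030 lower from compound 1 to compound 4 (within the scatter), so the two halogens cannot be told apart on this read-out. Within the data shown here, this is the first measured step on the fused ring, since the earlier step lay on the chain side of the molecule. Nothing measured here explains why the two halogens match. Still open, as far as these compounds go, is whether the maximal response holds with hydrogen, methoxy or trifluoromethyl on this carbon, with the rest of the molecule kept as in compound 1.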